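From 2-fluorophenyl to 3-chlorophenyl in compound 2

The compounds below may be only part of what the source reports. "The series", "measured", "known", "first", "only" and "open" are said of these compounds alone.

In a functional assay on U-937 cells (Homo sapiens) for antiproliferative activity, read by MTT assay, with a stated time of 24 h (on this read-out higher numbers stand for weaker inhibition of growth and lower numbers for stronger inhibition of growth), compound 1 (`Cc1ccc(NC(=O)C2(C)CCc3c(C)c(O)c(C)c(C)c3O2)cc1NC(=O)c1cnoc1C`) gives only a limit (> 30000 nM). Compound 2 (`Cc1ccc(NC(=O)Nc2ccccc2F)cc1NC(=O)c1cnoc1C`) likewise gives only a limit (> 30000 nM). Both stand at one limit (the limit of > 30000 nM in this assay, at which 2 of the 2 values shown sit), so neither offers a number to build on. Compound 3 (`Cc1ccc(NC(=O)Nc2cccc(Cl)c2)cc1NC(=O)c1cnoc1C`) carries 3-chlorophenyl in place of 2-fluorophenyl on an amide-type nitrogen. For the measured compounds named here, no measured step guides this change, and the expected move (a number no higher from compound 2 to compound 3 (the limit leaves the size open)) in this assay is none beyond the scatter, with a further limit quite likely. The estimate for compound 3 is 30000 nM with an expected range from 10000 nM to 50000 nM on this read-out.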

Compound 3, concentration for 50% growth inhibition: > 30000 nM
Compound 3 ended at the assay's limit (the forecaster's own chance of this, stated with the estimate: 70%); the middle value sits exactly at the limit.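

Compound 3, like compound 2, gives only a limit, so no step can be read between them: the limit of > 30000 nM in this assay, at which 3 of the 3 values shown sit.

The compounds shown leave open whether any group on the shared core would give a readable number in this assay.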